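The source may report more compounds than this note shows. Statements on the series, on what has been measured and on what is new or still open speak of the compounds shown alone.

In a functional assay on B16 cells (Mus musculus) for antiproliferative activity, read by MTT assay, with a stated time of 24 h (a lower number here means a stronger inhibitor, a higher number a weaker inhibitor), compound 1 (`COc1cc(OC)c(-c2coc3cc(OCC=C(C)C)ccc3c2=O)cc1OC`) gives 1090 nM while compound 2 (`COc1cc(OC)c(-c2coc3cc(OCc4ccccc4Cl)ccc3c2=O)cc1OC`) gives 4180 nM as the higher of the two numbers. For the measured compounds named here, the only measured step, a 3.8-fold higher number from compound 1 to compound 2 (0.58 log units; beyond the scatter) on placing 2-chlorophenyl where 2-methylprop-1-en-1-yl stood, is modest. Compound 3 (`COc1cc(OC)c(-c2coc3cc(OCc4ccc(C(F)(F)F)cc4)ccc3c2=O)cc1OC`) differs from compound 2 by 4-(trifluoromethyl)phenyl in place of 2-chlorophenyl on a saturated chain carbon bound to an oxygen on an aromatic ring with 4-(trifluoromethyl)phenyl in place of 2-chlorophenyl. Going by the values given here, no measured step exchanges one such phenyl group for another, and no step beyond the scatter is expected in this assay here. The expected step is a 1.2-fold lower number from compound 2 to compound 3 (0.08 log units; within the scatter) in size. Compound 3 is estimated at 3500 nM with an expected range from 1300 nM to 9000 nM overall.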

Compound 3, half-maximal inhibitory concentration: 5400 nM
Beside the measured number, compound 3's estimate is 1.5-fold (0.19 log units) below it; low and high end bracket the measured number.
By their numbers in this assay, from the lowest: compound 1; then compounds 2 and 3 (each within the scatter of the next).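

In this assay, exchanging one substituted phenyl group for another on a saturated chain carbon bound to an oxygen on an aromatic ring gives a 1.3-fold higher number from compound 2 to compound 3 (0.11 log units; within the scatter) and so leaves compound 2 and compound 3 indistinguishable. Replacing 2-methylprop-1-en-1-yl with 4-(trifluoromethyl)phenyl gives a 5.0-fold higher number from compound 1 to compound 3 (0.69 log units; beyond the scatter) and shows that a second phenyl-bearing compound also has a higher number than compound 1. Nothing available explains either step. From the compounds shown here alone, it remains open how a phenyl group carrying an amine or a carboxylic acid would read here. Going by these compounds, a longer chain in place of 2-methylprop-1-en-1-yl also remains open.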